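A chloro for a fluoro substituent: compound 4 expected

A few compounds are considered here, and "the series" means these few. Any claim that something is new, unique, unknown or untested is made for them only; others in the source may bear on it.

Three compounds share one core and differ only in the aryl group attached to it. In a functional assay on SNB-19 cells (Homo sapiens) for inhibition, read by sulforhodamine B assay, with a stated time of 48 h, tested at 10 uM (on this read-out higher numbers stand for more inhibition at the one concentration tested (going by the name of the read-out) and lower numbers for less inhibition), compound 1 `O=Cc1ccc(-c2cn3ccnc3c(-c3ccc4ncn(C5CCCCC5)c4c3)n2)cc1` gives 14.4%, compound 2 `c1ccc2c(-c3cn4ccnc4c(-c4ccc5ncn(C6CCCCC6)c5c4)n3)cccc2c1` gives 9.08%, and compound 3 `Fc1ccc(-c2cn3ccnc3c(-c3ccc4ncn(C5CCCCC5)c4c3)n2)cc1` gives 14.2%. Compound 3 stands close to compound 1, since a number 0.2 percentage points lower from compound 1 to compound 3 (within the scatter), and close to compound 2, since a number 5.1 percentage points higher from compound 2 to compound 3 (within the scatter); all three numbers lie within the scatter of one another. Compound 4 `Clc1ccc(-c2cn3ccnc3c(-c3ccc4ncn(C5CCCCC5)c4c3)n2)cc1` differs from compound 3 in one place: chloro in place of fluoro on an aromatic carbon. Among the compounds with values here, the nearest precedent is a change on the same aromatic carbon, where a number 0.2 percentage points lower from compound 1 to compound 3 (within the scatter), and the larger exchange a number 5.3 percentage points lower from compound 1 to compound 2 (within the scatter) also stayed within the scatter. Therefore no step beyond the scatter is expected for compound 4 in this assay. Compound 4 is expected to give 14%, in the range 6% to 22%, which means an expected step of a number 0.2 percentage points lower from compound 3 to compound 4 (within the scatter).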

Compound 4, a percentage reported as inhibition, at one concentration (the size of the read-out at that concentration, not a potency): 15.8%
The estimate for compound 4 lay 1.8 percentage points below the measured number; measured number inside the range.
By their numbers in this assay, from the lowest: compounds 2, 3, 1 and 4 (each within the scatter of the next).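

With chloro in place of fluoro on this aromatic carbon, para to a large group, the two halogens can now be compared directly: the result is a number 1.6 percentage points higher from compound 3 to compound 4 (within the scatter). The other exchanges ending at compound 4 also stay small, with a number 1.4 percentage points higher from compound 1 to compound 4 (within the scatter) and a number 6.7 percentage points higher from compound 2 to compound 4 (within the scatter), so none of the four aryl groups shown stands apart from the others on this read-out. Nothing available here explains this insensitivity. On these data alone, whether an amine or a carboxylic acid on this carbon would give a step beyond the scatter remains open.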